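Ester to Acid at a Shared Assay Limit

The source may report more compounds than this note shows. Statements on the series, on what has been measured and on what is new or still open speak of the compounds shown alone.

Compound 2 `COC(=O)[C@H](CCSC)NC(=O)c1ccc(NCc2cncn2Cc2ccc(C)cc2)cc1-c1ccccc1` stands only at a limit in a functional assay on NIH3T3 cells (Mus musculus); a lower number here means that less compound is needed, a higher number that more compound is needed for the effect: in that assay compound 2 gives > 10 uM, which is a limit of the assay and not a number. Compound 3 `COC(=O)[C@H](CCSC)NC(=O)c1ccc(NCc2cncn2Cc2cccc(C#N)c2)cc1-c1ccccc1` also sits at a limit; in this assay compound 3 gives > 10 uM. Compound 1 `CSCC[C@H](NC(=O)c1ccc(NCc2cncn2Cc2ccccc2C#N)cc1-c1ccccc1)C(=O)O` in this assay gives > 10 uM, again a limit. The step that the two limits leave unreadable from compound 2 to compound 3 is therefore unreadable, and the three values together show only (the limit of > 10 uM in this assay, at which 3 of the 3 values shown sit).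

Compound 4 `CSCC[C@H](NC(=O)c1ccc(NCc2cncn2Cc2ccc(C)cc2)cc1-c1ccccc1)C(=O)O` differs from compound 2 by hydrogen in place of methyl on an oxygen next to a carbonyl group. Among the compounds with values here, no measured step covers this change. Within the data shown here, compound 1 carries the same carboxy group, but no step is given between compound 1 and any other compound, and its value, like that of compound 2, is a limit. Among the measured compounds shown here, the only measured step, from compound 2 to compound 3, has no readable size, so nothing in this assay points to a step beyond the scatter in either direction for the change to compound 4. The value expected for compound 4 is 15 uM, within 5 uM and 60 uM, and the step expected is a step that the limit leaves unreadable from compound 2 to compound 4, with a result that most likely again comes back as a limit.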

Compound 4, concentration for half-maximal effect: > 10 uM
Compound 4: no number, only a limit; the forecaster's own chance of this, stated with the estimate: 80%; the middle value is on the limit's open side.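

In this assay compound 4 gives > 10 uM, a limit of the assay and not a number. No size can be read for the step to compound 4 from either compound 2 or compound 1: the limit of > 10 uM in this assay, at which 4 of the 4 values shown sit.

The compounds shown leave open whether methoxycarbonyl to carboxy changes the concentration needed at all, and how far any of the four lies past that limit.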